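Tetrazolylacetamide series: halogenated phenyl variation on the cyclohexyl core

The source may report more compounds than this note shows. Statements on the series, on what has been measured and on what is new or still open speak of the compounds shown alone.

Two compounds have numbers in an assay on HEK293 cells for activation of Kir3.1/Kir3.2 (Homo sapiens), read by thallium flux; a lower number here means that less compound is needed, a higher number that more compound is needed for the effect. Compound 1 `Cc1cc(NC(=O)Cn2nnc(-c3ccccc3)n2)n(C2CCC(F)(F)CC2)n1` gives 84 nM, while compound 2 `Cc1cc(NC(=O)Cn2nnc(-c3ccc(Cl)c(Cl)c3)n2)n(C2CCCCC2)n1` gives 1220 nM, the higher of the two values and a gap beyond the usual scatter; the pair differs in more than one place, so no single step can be read from it. Compound 3 `Cc1cc(NC(=O)Cn2nnc(-c3ccccc3F)n2)n(C2CCCCC2)n1` changes compound 2 by 2-fluorophenyl in place of 3,4-dichlorophenyl on an aromatic carbon. Within the data shown here, no measured step covers this change. The move toward a smaller halogenated phenyl, closer to the phenyl of compound 1 with its 84 nM, leads to an expected downward step of a 4.1-fold lower number from compound 2 to compound 3 (0.61 log units; beyond the scatter) in this assay. Compound 3 is therefore estimated at 300 nM, with a range of 80 nM to 1200 nM.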

Compound 3, half-maximal effective concentration: 187 nM
Estimate against measurement, compound 3: 1.6-fold (0.21 log units) above; the range from low to high includes it.
By their numbers in this assay, from the lowest: compound 1; then compound 3; then compound 2.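

On the aromatic carbon of the five-membered aromatic ring with 4 nitrogen, 2-fluorophenyl in place of 3,4-dichlorophenyl gives a 6.5-fold lower number from compound 2 to compound 3 (0.81 log units; beyond the scatter) in this assay. Among these compounds, this is the only single-place step so far, and it shows that this aryl change alone moves the number beyond the scatter. No available data explain the step. Going by these compounds, the change swaps halogen identity, number and placement together, so their separate contributions stay open. On these data alone, how a methoxy group, a nitrile or an amine on this phenyl would compare also stays open.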